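A few compounds are considered here, and "the series" means these few. Any claim that something is new, unique, unknown or untested is made for them only; others in the source may bear on it.

Measured in a functional assay on KYSE-450 cells (Homo sapiens) for inhibition, read by CCK-8 assay, with a stated time of 48 h; a higher number here means a weaker inhibitor, a lower number a stronger inhibitor:

- compound 1 `COc1ccc(CN(C(=O)CSC(=S)N2CCN(C(C)=O)CC2)c2cc(OC)c(OC)c(OC)c2)cc1`: 370 nM
- compound 2 `COc1ccc(CN(C(=O)CSC(=S)N2CCN(C(=O)OC(C)(C)C)CC2)c2cc(OC)c(OC)c(OC)c2)cc1O`: 76 nM
- compound 3 `CCN1CCN(C(=S)SCC(=O)N(Cc2ccc(OC)c(O)c2)c2cc(OC)c(OC)c(OC)c2)CC1`: 320 nM

In this assay, compound 3 gives 320 nM. This is level, within the usual scatter, with compound 1, while compound 2 is clearly the stronger inhibitor of the pair it forms with compound 3.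

The next compound to test is compound 4 `COc1ccc(CN(C(=O)CSC(=S)N2CCN(C(C)=O)CC2)c2cc(OC)c(OC)c(OC)c2)cc1O`. It puts acetyl in place of ethyl on an amine nitrogen in a ring, so the piperazine changes from 4-ethylpiperazin-1-yl to 4-acetylpiperazin-1-yl: acetyl in place of ethyl on an amine nitrogen in a ring.

Among the compounds with values here, only one measured step touches this nitrogen: a 4.2-fold higher number from compound 2 to compound 3 (0.62 log units; beyond the scatter). That modest loss came with ethyl replacing tert-butoxycarbonyl. Acetyl, like tert-butoxycarbonyl, is a carbonyl-bearing group, so moving away from ethyl may recover part of that loss, though probably not all of it. Within the data shown here, compound 1 also carries acetyl and gives 370 nM, but it differs from compound 4 elsewhere on the shared core, and no measured step isolates that difference.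

A modest move towards a lower number is therefore expected, and it could prove hard to separate from the scatter. The expected change is a 2.1-fold lower number from compound 3 to compound 4 (0.33 log units; beyond the scatter).

Compound 4 is estimated at 150 nM, with an expected range from 50 nM to 420 nM.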

Compound 4, half-maximal inhibitory concentration: 210 nM
Beside the measured number, compound 4's estimate is 1.4-fold (0.15 log units) below it; low and high end bracket the measured number.
By their numbers in this assay, from the lowest: compound 2; then compounds 4, 3 and 1 (each within the scatter of the next).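

In this assay the swap of ethyl for acetyl on the ring nitrogen gives a 1.5-fold lower number from compound 3 to compound 4 (0.18 log units; within the scatter) and so does not separate these two groups at this position, even though acetyl brings a carbonyl and a hydrogen-bond acceptor that ethyl lacks. The carbonyl alone therefore does not match compound 2: with the carbonyl kept, methyl in place of tert-butoxy gives a 2.8-fold higher number from compound 2 to compound 4 (0.44 log units; beyond the scatter) and the stronger inhibition here belongs to the whole tert-butoxycarbonyl group, not to every group with a carbonyl on this nitrogen. Within the data shown here, compound 4 also provides a first look at the aromatic hydroxy group with acetyl on the nitrogen, where hydroxy in place of hydrogen gives a 1.8-fold lower number from compound 1 to compound 4 (0.25 log units; within the scatter) and no clear effect can be claimed from this single pair.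

Nothing available explains any of these differences. Still open, on these data alone, is how a tert-butyl group attached directly to the ring nitrogen, a benzyloxycarbonyl group, or a plain hydrogen there would compare, which would show whether tert-butoxy needs the carbonyl to give its stronger inhibition.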